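Butyl removal on the selenium chain across two cores

This account rests on a few compounds, and the source may have more. Where it says the series, first, only, none or still open, it means among the compounds named here.

All numbers below come from a functional assay on CCRF-CEM cells (Homo sapiens) for cytotoxicity, read by MTT assay, with a stated time of 72 h; a lower number here means a stronger inhibitor of growth, a higher number a weaker inhibitor of growth.

Compound 1, `CCCCC[Se]c1nc(NCc2ccccc2)c2ccccc2n1`: 34500 nM
Compound 2, `CCCCC[Se]c1nc(N)c2cccnc2n1`: 12900 nM
Compound 3, `C[Se]c1nc(NCc2ccccc2)c2ccccc2n1`: 39800 nM

Compound 1 and compound 3 share a core and differ by hydrogen in place of butyl on a saturated chain carbon bound to a selenium atom. The step is a 1.2-fold higher number from compound 1 to compound 3 (0.06 log units; within the scatter), so on this core the shortened chain leaves the read-out essentially where it was.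

Compound 2 carries a different core; the difference between the two cores is not broken down here. Its value is the lowest of the three, and its steps to compound 1 and to compound 3 are both beyond the scatter.

Compound 4, `C[Se]c1nc(N)c2cccnc2n1`, is compound 2 with hydrogen in place of butyl on a saturated chain carbon bound to a selenium atom. This is the same change as that from compound 1 to compound 3, at the same place. The expected step is a 1.2-fold higher number from compound 2 to compound 4 (0.07 log units; within the scatter), resting on the measured step of a 1.2-fold higher number from compound 1 to compound 3 (0.06 log units; within the scatter) and on the value of compound 2, 12900 nM. Compound 4 is therefore estimated at 15000 nM, with a range of 7000 nM to 35000 nM.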

Compound 4, concentration for 50% growth inhibition: 68400 nM
Beside the measured number, compound 4's estimate is 4.6-fold (0.66 log units) below it; the whole stated range lies below it.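

In this assay, hydrogen in place of butyl on a saturated chain carbon bound to a selenium atom gives a 5.3-fold higher number from compound 2 to compound 4 (0.72 log units; beyond the scatter), so the change does not carry over with the same size from one core to the other: the same change on two cores in this assay, a 1.2-fold higher number (0.06 log units; within the scatter) from compound 1 to compound 3 and a 5.3-fold higher number (0.72 log units; beyond the scatter) from compound 2 to compound 4, 4.6-fold (0.66 log units) apart, beyond the scatter of two such steps. For these two pairs, then, a step read on the core of compound 1 is a poor guide to the step on the core of compound 2, and the butyl group counts for more on the latter. This does not show which feature of the two cores sets the gap, as the difference between them is not broken down, and two pairs give no general rule for the series.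

An ethyl or a propyl chain on the selenium atom would show whether growth inhibition on the core of compound 2 falls off gradually with chain length or only at the shortest chain. A longer chain, such as hexyl, would show whether the trend continues past butyl on either core.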